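Replacing Cyclohexyl by Oxanylmethyl on the Amide Carbonyl

The compounds below may be only part of what the source reports. "The series", "measured", "known", "first", "only" and "open" are said of these compounds alone.

Compound 1 `CC(=O)N1CCc2nc(C#Cc3ccccc3)sc2C1`: 90 nM
Compound 2 `O=C(C1CCCCC1)N1CCc2nc(C#Cc3ccccc3)sc2C1`: > 10000 nM

Both compounds were tested in an assay on HEK293 cells for negative allosteric modulation of metabotropic glutamate receptor 5 (Homo sapiens), read by FLIPR, with a stated time of 1 h; on this read-out lower numbers stand for stronger inhibition and higher numbers for weaker inhibition. Compound 1 gives 90 nM. For compound 2 the result is only a limit, > 10000 nM. Compound 2 thus sits at the weak end of what the numbers shown can tell, without an exact number (the limit of > 10000 nM in this assay, at which 1 of the 2 values shown sits). Among the measured compounds shown here, the single measured step, an at least 110-fold higher number from compound 1 to compound 2 (2.04 log units; beyond the scatter), shows that enlarging the group on the carbonyl carbon from methyl to cyclohexyl costs a great deal of potency.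

Compound 3 `O=C(CC1CCOCC1)N1CCc2nc(C#Cc3ccccc3)sc2C1` differs from compound 2 in one place: (oxan-4-yl)methyl in place of cyclohexyl on a carbonyl carbon. For the measured compounds named here, a bulky group stays on the carbonyl carbon, and the only step bearing on such bulk is an at least 110-fold higher number from compound 1 to compound 2 (2.04 log units; beyond the scatter). Nothing measured here separates a cyclohexyl from an oxanylmethyl at that position. Compound 3 is therefore expected to remain weak in this assay, quite possibly again reported only as a limit. The expected step is an at least 1.2-fold lower number from compound 2 to compound 3 (0.09 log units; that floor lies within the scatter). The estimate for compound 3 is 8000 nM, within a range from 1500 nM to 30000 nM.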

Compound 3, half-maximal inhibitory concentration: > 10000 nM
Compound 3 ended at the assay's limit; the forecaster's own chance of this, stated with the estimate: 55%; middle value at least 1.2-fold (0.09 log units) from the limit.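

Replacing hydrogen with oxan-4-yl on the saturated chain carbon bound to the carbonyl carbon gives an at least 110-fold higher number from compound 1 to compound 3 (2.04 log units; beyond the scatter) in this assay, so a second large group on the carbonyl carbon ends far weaker than the methyl of compound 1. This group differs from cyclohexyl in carrying a ring oxygen, counted as a hydrogen-bond acceptor, and one more heavy atom, yet that change does not bring a measured number back into view. The step between compound 2 and compound 3 cannot be read, and compound 3 joins compound 2 at the weak end of the read-out, so no order can be given for the two groups: the limit of > 10000 nM in this assay, at which 2 of the 3 values shown sit.

The compounds shown leave open how small a step up from methyl already costs potency, which a group such as ethyl or cyclopropyl on the carbonyl carbon could reveal. They also leave open whether a large group carrying a ring nitrogen, such as piperidin-4-ylmethyl, or a carboxylic acid on the chain would stay at the same limit.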